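Benzyl versus tert-butoxycarbonyl on the side-chain amine

The source may report more compounds than this note shows. Statements on the series, on what has been measured and on what is new or still open speak of the compounds shown alone.

Measured so far:
compound 1 `OC1(CNCc2ccccc2)CCN(CCCc2c[nH]c3ccc(-n4cnnc4)cc23)CC1`: 0.45 nM
compound 2 `CC(C)(C)OC(=O)NCC1(O)CCN(CCCc2c[nH]c3ccc(-n4cnnc4)cc23)CC1`: 21 nM

In an assay on CHO cells with 5-hydroxytryptamine receptor 1D (Homo sapiens) as the target (a lower number here means a stronger inhibitor, a higher number a weaker inhibitor), compound 1 gives 0.45 nM and compound 2 gives 21 nM. Among the measured compounds shown here, compound 2 stands at the higher of the two numbers; the single measured step between them, a 47-fold higher number from compound 1 to compound 2 (1.67 log units; beyond the scatter), is large and well beyond the scatter. Compound 3 `CN(Cc1ccccc1)CC1(O)CCN(CCCc2c[nH]c3ccc(-n4cnnc4)cc23)CC1` differs from compound 2 by benzyl(methyl)amino in place of (tert-butoxycarbonyl)amino on a saturated chain carbon bound to a saturated ring carbon. This change undoes the swap seen in the measured step, restoring the benzyl group while the amine additionally carries a methyl. For the measured compounds named here, the only relevant evidence is the step from compound 1 to compound 2, and since compound 3 moves back toward the benzyl arrangement of compound 1, a large decrease is expected, roughly of the size a 30-fold lower number from compound 2 to compound 3 (1.48 log units; beyond the scatter). Whether the added methyl shifts the number further is not answered by any measured pair, so the range is kept wide. For compound 3 the estimate in this assay is 0.7 nM, expected to fall between 0.2 nM and 3 nM.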

Compound 3, half-maximal inhibitory concentration: 1.2 nM
The estimate for compound 3 lay 1.7-fold (0.23 log units) below the measured number; the range from low to high includes it.
By their numbers in this assay, from the lowest: compound 1; then compound 3; then compound 2.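

In this assay, benzyl(methyl)amino in place of (tert-butoxycarbonyl)amino brings the number back down (an 18-fold lower number from compound 2 to compound 3 (1.24 log units; beyond the scatter)), so a large part of the loss seen with the carbamate is recovered once a benzyl group returns to this nitrogen. Methyl in place of hydrogen on the amine nitrogen gives a separate first reading at this position: a 2.7-fold higher number from compound 1 to compound 3 (0.43 log units; beyond the scatter) is a modest step, though beyond the scatter, and far smaller than a 47-fold higher number from compound 1 to compound 2 (1.67 log units; beyond the scatter). The data at hand offer no explanation for either step.

Still open, going by these compounds, is whether an ethyl or isopropyl group on this nitrogen would extend the methyl step. Also open, on these data alone, is how a cyclohexylmethyl or pyridylmethyl group in place of benzyl, or an acetyl group in place of tert-butoxycarbonyl, would compare.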